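Methyl in Place of Trifluoromethyl: Expecting Compound 4

The compounds below may be only part of what the source reports. "The series", "measured", "known", "first", "only" and "open" are said of these compounds alone.

Three compounds share one core and differ only in the aryl group on the amide-type nitrogen. Compound 2 `O=C(NCCCCC(c1ccc(F)cc1)c1ccc(F)cc1)Nc1ccc(C(F)(F)F)cc1` gives 2780 nM in a functional assay on MDA-MB-231 cells (Homo sapiens) for cytotoxicity, read by MTT assay, with a stated time of 48 h; a higher number here means a weaker inhibitor, a lower number a stronger inhibitor. Compound 1 `Cc1ccc(NC(=O)NCCCCC(c2ccc(F)cc2)c2ccc(F)cc2)cc1` carries methyl in place of trifluoromethyl on an aromatic carbon. In this assay compound 1 reaches only the limit > 20000 nM. That change gave an at least 7.1-fold higher number from compound 2 to compound 1 (0.85 log units; beyond the scatter). Compound 3 `O=C(NCCCCC(c1ccc(F)cc1)c1ccc(F)cc1)Nc1ccc(Cl)cc1C(F)(F)F` differs from compound 2 by 4-chloro-2-(trifluoromethyl)phenyl in place of 4-(trifluoromethyl)phenyl on an amide-type nitrogen. In this assay compound 3 likewise sits at the limit > 20000 nM. This step was an at least 7.1-fold higher number from compound 2 to compound 3 (0.85 log units; beyond the scatter), and both limits rest on (the limit of > 20000 nM in this assay, at which 2 of the 3 values shown sit).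

Compound 4 `Cc1cc(Cl)ccc1NC(=O)NCCCCC(c1ccc(F)cc1)c1ccc(F)cc1` takes from compound 3 the change (methyl in place of trifluoromethyl on an aromatic carbon), the same kind of change as from compound 2 to compound 1, though the place differs: para to a large group there, ortho to a large group and meta to a chloro group here. Because that change gave an at least 7.1-fold higher number from compound 2 to compound 1 (0.85 log units; beyond the scatter) and compound 3 already stands at a limit, the expected step in this assay is a step that the limit leaves unreadable from compound 3 to compound 4. Compound 4 is estimated at 35000 nM, between 15000 nM and 150000 nM.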

Compound 4, half-maximal inhibitory concentration: > 20000 nM
Compound 4: a limit, no number (the forecaster's own chance of this, stated with the estimate: 85%); the middle value lies beyond the limit too.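

In this assay compound 4 gives > 20000 nM, which is a limit and not a number. Going by these compounds alone, the change of trifluoromethyl to methyl therefore shows no measurable gain on this core, but whether it has the same effect here as on the core of compound 2 stays unknown, and the steps from compound 3 and from compound 1 to compound 4 cannot be read: the limit of > 20000 nM in this assay, at which 3 of the 4 values shown sit. The one readable new step swaps the whole aryl group, giving an at least 7.1-fold higher number from compound 2 to compound 4 (0.85 log units; beyond the scatter), so it shows only that compound 4 stays short of compound 2 and does not test the methyl change itself.

Among the compounds shown, only compound 2 gives a true number, so the size of any effect on the other aryl groups remains open. Also open, from the compounds shown here alone, is how a nitrile or a carboxylic acid on the aryl ring, or a longer chain on the shared core, would read in this assay.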